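Adding an Ethylcarbamoyl Group: Expected Cytotoxicity of Compound 4

The source may report more compounds than this note shows. Statements on the series, on what has been measured and on what is new or still open speak of the compounds shown alone.

Of the compounds shown here, three sharing one core have been tested in an ADME assay on L929 cells (Mus musculus) for cytotoxicity, read by resazurin assay, with a stated time of 72 h; a higher number here means a weaker inhibitor, a lower number a stronger inhibitor. Compound 1 `OB1OCc2ccc(-n3cc(Sc4ccc5ccccc5c4)c4ccccc43)cc21` gives > 10 ug/mL, which is a limit of the assay rather than a number. Compound 2 `COc1ccc(S(=O)(=O)c2cn(-c3ccc4c(c3)B(O)OC4)c3ccccc23)cc1` likewise returns > 10 ug/mL, again a limit. Compound 3 `OB1OCc2ccc(-n3cccc3)cc21`, the smallest of the three, also gives > 10 ug/mL, once more a limit. All three therefore rest at the limit of > 10 ug/mL in this assay, at which 3 of the 3 values shown sit, and none of them can be set apart from the others on these readings.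

Compound 4 `CCNC(=O)c1cccn1-c1ccc2c(c1)B(O)OC2` has not yet been measured. Relative to compound 3 it carries ethylcarbamoyl in place of hydrogen on an aromatic carbon. No measured step between any two of these compounds exists to show how such a change moves the reading. Because compound 3 sits at the limit of > 10 ug/mL in this assay, at which 3 of the 3 values shown sit, together with the two far larger compounds, the expected step that the limit leaves unreadable from compound 3 to compound 4 is not expected to go beyond the usual scatter. Compound 4 is therefore estimated at 15 ug/mL, between 6 ug/mL and 40 ug/mL, with a strong chance that the assay again reports only a limit.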

Compound 4, half-maximal inhibitory concentration: > 10 ug/mL
Compound 4 gave a limit, no number; the forecaster's own chance of this, stated with the estimate: 80%; the middle value does not contradict the limit.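

No step can be read from compound 3 to compound 4, as both results in this assay are limits and not numbers: the limit of > 10 ug/mL in this assay, at which 4 of the 4 values shown sit.

The compounds shown leave open whether ethylcarbamoyl in place of hydrogen on an aromatic carbon shifts cytotoxicity at all, and where any of the four compounds would fall as a number.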